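The source may report more compounds than this note shows. Statements on the series, on what has been measured and on what is new or still open speak of the compounds shown alone.

Three compounds sharing a core were measured in a functional assay on MCF7 cells (Homo sapiens) for antiproliferative activity; on this read-out lower numbers stand for stronger inhibition and higher numbers for weaker inhibition. Compound 1 `C/C(=N\Nc1nc(-c2ccc(Br)cc2)cs1)c1cc2ccccc2o1` gives 33200 nM, compound 2 `COc1ccc(-c2csc(N/N=C(\C)c3cc4ccccc4o3)n2)cc1` gives 18900 nM, and compound 3 `C/C(=N\Nc1nc(-c2ccccc2)cs1)c1cc2ccccc2o1` gives 8490 nM. Compound 3 thus stands lowest of the three, and both gaps to it lie beyond the scatter: exchanging bromo for methoxy, a 1.8-fold lower number from compound 1 to compound 2 (0.24 log units; within the scatter), stays within the scatter, whereas a 3.9-fold lower number from compound 1 to compound 3 (0.59 log units; beyond the scatter) and a 2.2-fold lower number from compound 2 to compound 3 (0.35 log units; beyond the scatter) are modest steps beyond it, so compound 3 is the most potent of the three measured.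

Compound 4 `CCOC(=O)Cc1csc(N/N=C(\C)c2cc3ccccc3o2)n1` differs from compound 3 by (ethoxycarbonyl)methyl in place of phenyl on an aromatic carbon. None of the three measured steps bears directly on this change: each of them only swaps a substituent on the phenyl, while here the whole phenyl is exchanged for a chain with no ring. Within the data shown here, the measured steps show that the unsubstituted phenyl gave the lowest number, but there is no example of removing it altogether. The expectation for compound 4 is therefore a rise in this assay, expressed as a 2.1-fold higher number from compound 3 to compound 4 (0.33 log units; beyond the scatter), with wide uncertainty on either side. Compound 4 is estimated at 18000 nM, with a range from 5000 nM to 70000 nM.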

Compound 4, half-maximal inhibitory concentration: 6550 nM
The estimate for compound 4 lay 2.7-fold (0.44 log units) above the measured number; the range from low to high includes it.
By their numbers in this assay, from the lowest: compounds 4 and 3 (each within the scatter of the next); then compounds 2 and 1 (each within the scatter of the next).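

In this assay the phenyl on this aromatic carbon, next to the ring nitrogen, proves dispensable: (ethoxycarbonyl)methyl in its place gives a 1.3-fold lower number from compound 3 to compound 4 (0.11 log units; within the scatter) and so leaves the two compounds indistinguishable, even though the new group has no ring and carries two hydrogen-bond acceptors. The same group also compares well with the substituted rings, with a 2.9-fold lower number from compound 2 to compound 4 (0.46 log units; beyond the scatter) against the 4-methoxyphenyl and a 5.1-fold lower number from compound 1 to compound 4 (0.70 log units; beyond the scatter) against the 4-bromophenyl, so among these four compounds an aromatic ring at this position is not required for the lowest numbers seen. Nothing at hand explains why a plain phenyl and this ring-free chain land at the same level.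

Going by these compounds, it remains open whether the ester matters or any small chain would do, a question that the matching carboxylic acid, an amide or a plain ethyl group at this position could settle. On these data alone, the effect of chain length also remains open, as a longer chain carrying the same ester could behave differently from (ethoxycarbonyl)methyl.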